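One ring substituent swapped: expected effect on cell cytotoxicity

The source may report more compounds than this note shows. Statements on the series, on what has been measured and on what is new or still open speak of the compounds shown alone.

Compound 1, `COc1ccc(N2CCN(CC(=O)N3CCN(c4nnc(-c5ccc(C)cc5)c(-c5ccc(C)cc5)n4)CC3)CC2)cc1`: 116000 nM
Compound 2, `COc1cccc(N2CCN(CC(=O)N3CCN(c4nnc(-c5ccc(Cl)cc5)c(-c5ccc(Cl)cc5)n4)CC3)CC2)c1`: 202000 nM

Both numbers come from an ADME assay on NIH3T3 cells (Mus musculus) for cytotoxicity, read by MTT assay, with a stated time of 24 h (on this read-out higher numbers stand for weaker inhibition and lower numbers for stronger inhibition), a test of how strongly each compound harms mouse fibroblast cells in culture. In this assay compound 2 gives 202000 nM, the higher of the two numbers shown. Compound 1, however, gives 116000 nM in this assay, and the gap between the two lies within the usual scatter of repeated measurements, so the two compounds cannot be told apart on cytotoxicity. Both are very weak cell poisons.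

Compound 3, `O=C(CN1CCN(c2ccc(Cl)cc2)CC1)N1CCN(c2nnc(-c3ccc(Cl)cc3)c(-c3ccc(Cl)cc3)n2)CC1`, is the next compound to be measured. It differs from compound 2 in one place: 4-chlorophenyl in place of 3-methoxyphenyl on an amine nitrogen in a ring. Among the compounds with values here, no pair of measured compounds in this set shows what such a swap does, so there is no measured step to lean on. Within the data shown here, the two measured compounds, which differ elsewhere in the molecule, are indistinguishable, and that is the only guide available. The expectation for compound 3 is therefore a step of a 1.1-fold lower number from compound 2 to compound 3 (0.05 log units; within the scatter) in this assay, none beyond the scatter. Compound 3 is estimated at 180000 nM in this assay, within a range from 90000 nM to 400000 nM.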

Compound 3, half-maximal inhibitory concentration: > 803000 nM
Compound 3: no number, only a limit; the forecaster's own chance of this, stated with the estimate: 15%; at least 4.4-fold (0.64 log units) between middle value and limit.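

Compound 3 gives > 803000 nM in this assay, and this is a limit of the assay, not a number. With 4-chlorophenyl in place of 3-methoxyphenyl on an amine nitrogen in a ring, the data show an at least 3.9-fold higher number from compound 2 to compound 3 (0.59 log units; beyond the scatter), so the group at this position can shift the read-out beyond the scatter, here towards weaker harm to the cells, which the earlier pair could not show. Only a lower bound on this step can be read, and it rests on a single compound at the end of the measured range: the limit of > 803000 nM in this assay, at which 1 of the 3 values shown sits.

The names 3-methoxyphenyl and 4-chlorophenyl differ both in the substituent and in the number that gives its place on the ring, so the step cannot say which of the two differences matters, or whether both do. From the compounds shown here alone, how a plain phenyl group without any substituent, or a phenyl ring carrying a carboxylic acid, would behave on the same ring nitrogen stays open, as does whether the step would hold on a core carrying other groups.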